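Aryl swap at the biaryl position in the permeability series

The source may report more compounds than this note shows. Statements on the series, on what has been measured and on what is new or still open speak of the compounds shown alone.

Working notes on the series. Compound 1 `COc1cccc(CNCCCNc2ccnc3cc(-c4ccc(C(C)(C)C)cc4)ccc23)c1O` and compound 2 `CC(C)(C)c1ccc(-c2ccc3c(NCCCNCc4ccco4)ccnc3c2)cc1` share one core and differ only at the saturated chain carbon bound to an amine nitrogen. In an ADME assay for permeability, using PAMPA, with a stated time of 30 min, at pH 7.4 (on this read-out higher numbers stand for higher permeability and lower numbers for lower permeability), compound 1 gives 237 10^-6 cm/s, and compound 2 gives 237 10^-6 cm/s. Among the measured compounds shown here, the single measured step, no change at the digits printed from compound 1 to compound 2 (within the scatter), shows that exchanging furan-2-yl for 2-hydroxy-3-methoxyphenyl at that chain carbon leaves the read-out where it was. For the measured compounds named here, on the numbers so far, compound 2 stands level with compound 1, with nothing to separate the two beyond the scatter.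

Compound 3 `c1coc(CNCCCNc2ccnc3cc(-c4cccc5ccccc45)ccc23)c1` is not yet measured. It differs from compound 2 at an aromatic carbon: naphthalen-1-yl in place of 4-(tert-butyl)phenyl on an aromatic carbon. Going by the values given here, no measured step touches this aromatic carbon, so the one available step, from compound 1 to compound 2, bears on it only indirectly: it shows the read-out is insensitive to a swap of comparable size elsewhere in the molecule. The exchanged groups are matched in heavy-atom count and carry no donors or acceptors. The step from compound 2 to compound 3 in this assay is therefore expected to be no change at the digits printed from compound 2 to compound 3 (within the scatter), that is, none beyond the scatter. Compound 3 is estimated at 237 10^-6 cm/s, within 120 10^-6 cm/s to 400 10^-6 cm/s.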

Compound 3, apparent permeability: 237 10^-6 cm/s
For compound 3 middle estimate and measured number coincide at the digits printed; low and high end bracket the measured number.
By their numbers in this assay, from the lowest: compounds 1, 2 and 3 (each within the scatter of the next).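

The aromatic carbon now has a measured step of its own: in this assay, naphthalen-1-yl in place of 4-(tert-butyl)phenyl gives no change at the digits printed from compound 2 to compound 3 (within the scatter), although the entering group carries two six-membered aromatic rings of carbon only where the leaving group carries one. The exchange is matched in heavy-atom count, and neither group has hydrogen-bond donors or acceptors, so this step tests a change of ring count and shape of the aryl group, not a change in those counts. Each of the two places varied in the series now has one measured step, and neither step moves the read-out beyond the scatter; no information available here speaks to the reason for this.

The compounds shown leave open whether a group bearing heteroatoms at this aromatic carbon, such as pyridin-3-yl, a carboxylic acid or a dimethylamino-substituted phenyl, would hold the read-out as these two carbon-only groups do. They also leave open whether a shorter or longer chain between the two amine nitrogens would move this assay at all, since no step shown departs from the scatter.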